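Replacing fluoro with methylsulfonyl on a shared core

A few compounds are considered here, and "the series" means these few. Any claim that something is new, unique, unknown or untested is made for them only; others in the source may bear on it.

Of the compounds shown here, three with one shared core have been measured. Compound 1 `O=c1c(-c2nn[nH]n2)c[nH]c2c(F)ccc(F)c12` gives 10 mg/kg in a functional assay on the whole organism (strain Sprague-Dawley) for inhibition, with Rattus norvegicus as the target; a lower number here means that less compound is needed, a higher number that more compound is needed for the effect. Compound 2 `O=c1c(-c2nn[nH]n2)c[nH]c2c(F)cccc12` gives 10 mg/kg in this assay, so that no change at the digits printed from compound 1 to compound 2 (within the scatter). Compound 3 `Cc1cc(F)c2[nH]cc(-c3nn[nH]n3)c(=O)c2c1` shows only a limit, > 10 mg/kg, in this assay. Accordingly a number no lower from compound 2 to compound 3 (the limit leaves the size open); its size is hidden by the limit of > 10 mg/kg in this assay, at which 1 of the 3 values shown sits. Compound 4 `CS(=O)(=O)c1cccc2c(=O)c(-c3nn[nH]n3)c[nH]c12` is not yet measured; it differs from compound 2 by methylsulfonyl in place of fluoro on an aromatic carbon. Among the measured compounds shown here, no measured step concerns methylsulfonyl, and the two known steps show either no change or an unreadable size, so the expected step of no change at the digits printed from compound 2 to compound 4 (within the scatter) is one of no change beyond the scatter. Compound 4 is therefore estimated at 10 mg/kg, with a range from 3 mg/kg to 30 mg/kg.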

Compound 4, minimum effective dose: > 25 mg/kg
Compound 4 ended at the assay's limit (the forecaster's own chance of this, stated with the estimate: 40%); middle value at least 2.5-fold (0.39 log units) from the limit.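

Methylsulfonyl in place of fluoro on this aromatic carbon gives an at least 2.5-fold higher number from compound 2 to compound 4 (0.39 log units; beyond the scatter) in this assay, the only readable step beyond the scatter among the compounds shown. Among the compounds shown here, the position therefore does not accept every group equally, which the earlier compounds could not show. For compound 4 the value is a limit, so the upper size of the step stays open: the limit of > 25 mg/kg in this assay, at which 1 of the 4 values shown sits.

The compounds shown leave open how an amine, a methoxy group or a longer chain on this aromatic carbon would read in this assay.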